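The source may report more compounds than this note shows. Statements on the series, on what has been measured and on what is new or still open speak of the compounds shown alone.

Working notes on the series. Compound 1 `Cc1ccc(NC(=O)c2cccc(C(F)(F)F)c2)cc1N1Cc2cnc(Nc3ccc(C)c(C(F)(F)F)c3)nc2N(C)C1=O` and compound 2 `Cc1ccc(NC(=O)c2cccc(C(F)(F)F)c2)cc1N1Cc2cnc(OC3CCNCC3)nc2N(C)C1=O` share one core; compound 2 carries (piperidin-4-yl)oxy where compound 1 carries (4-methyl-3-(trifluoromethyl)phenyl)amino on the same aromatic carbon. In an ADME assay on BaF3 cells (Mus musculus) for antiproliferative activity, read by CellTiter-Glo and CCK-8 assay, with a stated time of 72 h (a lower number here means a stronger inhibitor of growth, a higher number a weaker inhibitor of growth), compound 1 returns only a limit of the assay, > 10000 nM. In this assay compound 2 likewise returns only a limit, > 10000 nM. The step that the two limits leave unreadable from compound 1 to compound 2 is therefore not readable, because of the limit of > 10000 nM in this assay, at which 2 of the 2 values shown sit. Compound 2 thus stands at the limit, with no numbered value among the two compounds shown.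

Compound 3 `Cc1ccc(Oc2ncc3c(n2)N(C)C(=O)N(c2cc(NC(=O)c4cccc(C(F)(F)F)c4)ccc2C)C3)cc1N` follows from compound 2 by 3-amino-4-methylphenyl in place of piperidin-4-yl on an oxygen on an aromatic ring. Among the measured compounds shown here, no measured step bears on this change; the only measured step is unreadable, so it gives no direction for the step in this assay. Compound 3 is expected to sit at 10000 nM, within a range of 2500 nM to 40000 nM. The estimate implies a step of a number no higher from compound 2 to compound 3 (the limit leaves the size open), expected to be no more than the scatter.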

Compound 3, concentration for 50% growth inhibition: > 10000 nM
Compound 3: only a limit was reported; the forecaster's own chance of this, stated with the estimate: 70%; the middle value sits exactly at the limit.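

Compound 3 gives only a limit in this assay, so its steps from compound 1 and compound 2 cannot be read, because all three compounds sit at the same limit: (the limit of > 10000 nM in this assay, at which 3 of the 3 values shown sit). The compounds shown leave open how compound 1, compound 2 and compound 3 rank in this assay, and which group on the shared core would give a numbered value.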